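The source may report more compounds than this note shows. Statements on the series, on what has been measured and on what is new or still open speak of the compounds shown alone.

Working notes on the hydroxyphenyl-pyridine series.

Compound 1 `Oc1ccc(-c2cc(-c3ccccc3O)cc(-c3cccc(O)c3)n2)cc1` gives 650 nM in a functional assay on T47D cells (Homo sapiens) for cytotoxicity, read by CCK-8 assay, with a stated time of 4 days; a lower number here means a stronger inhibitor, a higher number a weaker inhibitor. Within the data shown here, compound 2 `Oc1ccc(-c2cc(-c3ccccc3O)cc(-c3ccccc3O)n2)cc1` gives 960 nM in this assay, and its number is the highest of the two measured so far; the single step recorded, a 1.5-fold higher number from compound 1 to compound 2 (0.17 log units; within the scatter), lies within the scatter, so the two compounds cannot be ordered.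

Compound 3 `Oc1ccc(-c2cc(-c3ccc(O)cc3)nc(-c3ccccc3O)c2)cc1` has not been measured. It differs from compound 2 as follows: 4-hydroxyphenyl in place of 2-hydroxyphenyl on an aromatic carbon. Among the measured compounds shown here, the only step that bears on moving a hydroxyl around a phenyl ring on the shared core is a 1.5-fold higher number from compound 1 to compound 2 (0.17 log units; within the scatter), which was within the scatter. On that basis the change from compound 2 to compound 3 is expected to produce no step beyond the scatter in this assay, in either direction, and the expected step is a 1.2-fold lower number from compound 2 to compound 3 (0.08 log units; within the scatter). For compound 3 the estimate in this assay is 800 nM, with a range from 350 nM to 1800 nM.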

Compound 3, half-maximal inhibitory concentration: 50000 nM
Estimate against measurement, compound 3: 63-fold (1.80 log units) below; the measured number lies above the stated range.
By their numbers in this assay, from the lowest: compounds 1 and 2 (each within the scatter of the next); then compound 3.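

The position opposite the ring nitrogen is sensitive to where the hydroxyl sits on its phenyl ring: in this assay, 4-hydroxyphenyl in place of 2-hydroxyphenyl there gives a 52-fold higher number from compound 2 to compound 3 (1.72 log units; beyond the scatter), although the two groups have the same atoms and the same counts of donors and acceptors. The earlier step changed a different place on the shared core and stayed within the scatter, so it did not carry over to this position, and the readout here depends on the site as well as on the kind of change. Nothing available accounts for the size of this step.

Still open, as far as these compounds go, is how a 3-hydroxyphenyl group would read at this position. Also open, from the compounds shown here alone, is whether the hydroxyl of the 2-hydroxyphenyl group matters there at all, which a plain phenyl, a 2-methoxyphenyl or a 2-aminophenyl group at the same carbon would address.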